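Trimming a Second Methoxy Group on Compound 2

The source may hold more compounds than are shown below. What is called first, only, known or untested is meant among the compounds shown, and "the series" means these compounds.

Of the compounds shown here, two sharing one core have been tested in a functional assay on HOP-92 cells (Homo sapiens) for inhibition, read by sulforhodamine B assay, with a stated time of 48 h; on this read-out lower numbers stand for stronger inhibition of growth and higher numbers for weaker inhibition of growth. Compound 1 `COc1cc(CNc2nc3cc(N)cc(N)c3nc2-c2ccccc2)cc(OC)c1OC` gives 1200 nM, and compound 2 `COc1ccc(CNc2nc3cc(N)cc(N)c3nc2-c2ccccc2)cc1OC` gives 13500 nM. Of these two numbers, compound 2 stands at the higher one, meaning weaker inhibition of growth. Among the compounds with values here, the single structural change behind that difference, hydrogen in place of methoxy on an aromatic carbon, brought an 11-fold higher number from compound 1 to compound 2 (1.05 log units; beyond the scatter). Compound 3 `COc1ccc(CNc2nc3cc(N)cc(N)c3nc2-c2ccccc2)cc1` carries the same kind of change one step further: hydrogen in place of methoxy on an aromatic carbon. Within the data shown here, only one measured step bears on this, the one from compound 1 to compound 2, and it was large and toward weaker inhibition. A second removal need not repeat that size, so a smaller rise is expected, with wide uncertainty. For compound 3 the expected result in this assay is 25000 nM, within a range from 8000 nM to 80000 nM, a step of a 1.9-fold higher number from compound 2 to compound 3 (0.27 log units; within the scatter).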

Compound 3, concentration for 50% growth inhibition: 12900 nM
The estimate for compound 3 lay 1.9-fold (0.29 log units) above the measured number; measured number inside the range.
By their numbers in this assay, from the lowest: compound 1; then compounds 3 and 2 (each within the scatter of the next).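

In this assay, replacing this methoxy group with hydrogen turns the 3,4-dimethoxyphenyl group into 4-methoxyphenyl and gives a 1.0-fold lower number from compound 2 to compound 3 (0.02 log units; within the scatter), so compound 2 and compound 3 cannot be told apart at this position. The same kind of change therefore does not carry the same size each time, since the earlier replacement gave an 11-fold higher number from compound 1 to compound 2 (1.05 log units; beyond the scatter), which lies beyond the scatter. Nothing available here explains why these two steps differ in size.

Still open, on these data alone, is whether the remaining methoxy group matters, which a plain phenyl ring carrying hydrogen in its place would test. As far as these compounds go, it is also open whether a hydroxyl group or an amine at the position studied here would bring the number closer to that of compound 1 (1200 nM).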